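Bromo to cyano: what the sulfonyl neighbours suggest

This account rests on a few compounds, and the source may have more. Where it says the series, first, only, none or still open, it means among the compounds named here.

Compound 1 `O=C1/C(=C/c2ccncc2)CN(S(=O)(=O)c2ccc(F)cc2)C/C1=C\c1ccccc1C(F)(F)F`: 9270 nM
Compound 2 `O=C1/C(=C/c2ccncc2)CN(S(=O)(=O)c2ccc(Br)cc2)C/C1=C\c1ccccc1C(F)(F)F`: 10500 nM

Both numbers come from a functional assay on SMMC-7721 cells (Homo sapiens) for cytotoxicity, read by MTT assay, with a stated time of 24 h; a lower number here means a stronger inhibitor, a higher number a weaker inhibitor. For the measured compounds named here, compound 2, at 10500 nM, cannot be told apart from the only other measured compound, since the gap lies within the usual scatter of repeated measurements.

The next compound is compound 3 `N#Cc1ccc(S(=O)(=O)N2C/C(=C\c3ccncc3)C(=O)/C(=C/c3ccccc3C(F)(F)F)C2)cc1`, which keeps the shared core and changes a single group: cyano in place of bromo on an aromatic carbon. In plain words, cyano takes the place of bromo on an aromatic carbon, para to a large group.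

Going by the values given here, only one measured step bears on this change, the swap of fluoro for bromo on that same aromatic carbon. That step, a 1.1-fold higher number from compound 1 to compound 2 (0.05 log units; within the scatter), stayed within the scatter, so exchanging these two groups made no visible difference. Among the compounds with values here, a single step is thin evidence, however, and no cyano compound has been measured yet. The estimated step is a 1.1-fold lower number from compound 2 to compound 3 (0.02 log units; within the scatter), so no change beyond the scatter is expected. For compound 3 the expected value is 10000 nM, with an estimated range of 4500 nM to 20000 nM.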

Compound 3, half-maximal inhibitory concentration: 9610 nM
Compound 3: the middle estimate sits 1.0-fold (0.02 log units) above what was measured; the range from low to high includes it.
By their numbers in this assay, from the lowest: compounds 1, 3 and 2 (each within the scatter of the next).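

In this assay, for the compounds shown here, the swap of bromo for cyano gives a 1.1-fold lower number from compound 2 to compound 3 (0.04 log units; within the scatter) and the swap of fluoro for cyano gives a 1.0-fold higher number from compound 1 to compound 3 (0.02 log units; within the scatter) with no step standing out from the scatter, so all three groups on this aromatic carbon, para to a large group, give numbers that cannot be told apart. The earlier pair compared only two halogens, each a single heavy atom with no hydrogen-bond acceptor, whereas cyano brings two heavy atoms, a triple bond and one hydrogen-bond acceptor, and even this different kind of group leaves the number within the scatter of the other two. Nothing available here explains why the three compounds read alike, so the result stands as an observation without a measured reason.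

Three groups on one carbon, in one cell assay, cannot show how far this indifference extends, and an amine, a carboxylic acid or a longer chain such as butyl at the same place could still behave differently. The compounds shown also leave open whether a change elsewhere on the shared core would move the number beyond the scatter.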